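Phenyl in place of 2-fluoropyridin-4-yl: outlook for maximal response

This account rests on a few compounds, and the source may have more. Where it says the series, first, only, none or still open, it means among the compounds named here.

Compound 3 `O=C(O)Cc1sc(C(c2ccc(F)cc2)c2ccc(F)cc2)nc1-c1ccnc(F)c1` reaches 80% in an in vitro functional assay on HEK285-7 cells for antagonist activity at prostaglandin D2 receptor 2 (Homo sapiens), read by BRET and beta-arrestin recruitment; a higher number here means a larger maximal response, a lower number a smaller maximal response. Compound 1 `O=C(O)Cc1sc(C(c2ccc(F)cc2)c2ccc(F)cc2)nc1-c1ccnc(N2CCCC2)c1` gives 80% and compound 2 `O=C(O)Cc1sc(C(c2ccc(F)cc2)c2ccc(F)cc2)nc1-c1ccnc(Cl)c1` gives 80% in this assay, and the steps of no change at the digits printed from compound 1 to compound 3 (within the scatter) and no change at the digits printed from compound 2 to compound 3 (within the scatter) leave compound 3 level with both. Compound 4 `O=C(O)Cc1sc(C(c2ccc(F)cc2)c2ccc(F)cc2)nc1-c1ccccc1` differs from compound 3 in one place: phenyl in place of 2-fluoropyridin-4-yl on an aromatic carbon. The measured steps, including no change at the digits printed from compound 1 to compound 2 (within the scatter), only swap the substituent on the six-membered ring and keep its ring nitrogen, so they bear on this change indirectly; they show the maximal response unmoved by varied groups at this part of the molecule. No step beyond the scatter is therefore expected in this assay for compound 4, estimated at 80% with a range of 70% to 90%. This corresponds to an expected no change at the digits printed from compound 3 to compound 4 (within the scatter).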

Compound 4, largest response reached (reported as efficacy), in percent of the reference or control that the assay uses: 80%
The estimate for compound 4 equals the measured number at the digits printed; the measured number falls inside the stated range.
By their numbers in this assay, from the lowest: compounds 1, 2, 3 and 4 (each within the scatter of the next).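

Taking out the ring nitrogen along with the substituent, a change the earlier compounds did not include, leaves the maximal response in this assay flat against all three pyridines (no change at the digits printed from compound 3 to compound 4 (within the scatter); no change at the digits printed from compound 2 to compound 4 (within the scatter); no change at the digits printed from compound 1 to compound 4 (within the scatter)). This position therefore accepts a carbon-only phenyl as well as the substituted pyridines of compounds 1, 2 and 3. No supporting data are at hand to explain this result. Still open, from the compounds shown here alone, is whether a saturated cyclohexyl in place of phenyl, or an amine or carboxylic acid on the phenyl, would keep this maximal response.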